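This account rests on a few compounds, and the source may have more. Where it says the series, first, only, none or still open, it means among the compounds named here.

Of the compounds shown here, two have so far been tested in a functional assay on MGC-803 cells (Homo sapiens) for cytotoxicity, read by MTT assay, with a stated time of 72 h; on this read-out lower numbers stand for stronger inhibition and higher numbers for weaker inhibition. Compound 1 `O=C(NC(=S)NNc1ncnc2ccccc12)c1ccccc1F` gives 5010 nM. Compound 2 `COc1cc2ncnc(NNC(=S)NC(=O)c3ccc(C(F)(F)F)cc3)c2cc1OC`, built on a different core, gives 9280 nM in this assay, and the two numbers lie within the usual scatter of each other, so neither can be called the stronger. Compound 3 `O=C(NC(=S)NNc1ncnc2ccccc12)c1cccc(Cl)c1` keeps the core of compound 1 and differs in one place: 3-chlorophenyl in place of 2-fluorophenyl on a carbonyl carbon. Among the compounds with values here, no measured pair shows what such a swap does, so in this assay a step of modest size in either direction, or none beyond the scatter, is expected. Compound 3 is therefore estimated at 4500 nM, with a range from 1500 nM to 14000 nM. The expected step of a 1.1-fold lower number from compound 1 to compound 3 (0.05 log units; within the scatter) is small.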

Compound 3, half-maximal inhibitory concentration: 4540 nM
For compound 3 the middle estimate is 1.0-fold (0.00 log units) below the measured one; the range from low to high includes it.
By their numbers in this assay, from the lowest: compounds 3, 1 and 2 (each within the scatter of the next, the first and the last beyond it).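

In this assay, within the data shown here, replacing 2-fluorophenyl with 3-chlorophenyl on a carbonyl carbon gives a 1.1-fold lower number from compound 1 to compound 3 (0.04 log units; within the scatter) and this is the first measured pair that differs in one place. On the shared core, this position therefore takes either of these two halogen-bearing phenyl groups with no difference that can be told from the scatter. Nothing measured here offers an explanation for this result. Still open, going by these compounds, is whether a group of another kind at this place, such as an amine or a longer alkyl chain, would move the number beyond the scatter.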